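The source may hold more compounds than are shown below. What is called first, only, known or untested is meant among the compounds shown, and "the series" means these compounds.

Measured compounds:
compound 1, `C1CCC(c2nnc3nnc(N4CCCC4)nn23)CC1`: 22000 nM
compound 2, `O=[N+]([O-])c1ccc(-c2nnc3nnc(N4CCCC4)n3n2)cc1`: > 100000 nM
compound 3, `O=[N+]([O-])c1ccc(-c2nnc3nnc(N4CCCCC4)n3n2)cc1`: > 100000 nM

In a functional assay on BeWo cells (Homo sapiens) for cytotoxicity, read by MTT assay, with a stated time of 72 h (a higher number here means a weaker inhibitor, a lower number a stronger inhibitor), compound 1 gives 22000 nM. Compound 2 gives only a limit, > 100000 nM. Compound 3 likewise gives only a limit, > 100000 nM, so compound 3 stands at the top end of the measured range, with no number of its own; (the limit of > 100000 nM in this assay, at which 2 of the 3 values shown sit). Among the compounds with values here, the one measured step, a step that the two limits leave unreadable from compound 2 to compound 3, cannot be read in size.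

Compound 4, `COc1ccc(-c2nnc3nnc(N4CCCCC4)n3n2)cc1`, differs from compound 3 by methoxy in place of nitro on an aromatic carbon. Within the data shown here, no measured step bears on this change, so no direction can be taken from the data beyond the scatter. Compound 4 is therefore expected near 80000 nM, between 20000 nM and 300000 nM, which means an expected step of an at least 1.2-fold lower number from compound 3 to compound 4 (0.09 log units; that floor lies within the scatter).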

Compound 4, half-maximal inhibitory concentration: > 100000 nM
Compound 4 was reported as a limit; the forecaster's own chance of this, stated with the estimate: 50%; at least 1.2-fold (0.09 log units) between middle value and limit.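

Compound 3 and compound 4 are both reported only as limits, so no step can be read between them: the limit of > 100000 nM in this assay, at which 3 of the 4 values shown sit. The compounds shown leave open whether nitro or methoxy gives the stronger inhibitor.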